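Half-life after a piperazine-to-aminopiperidine swap

The source may hold more compounds than are shown below. What is called first, only, known or untested is meant among the compounds shown, and "the series" means these compounds.

Compound 2 `Cc1cn(-c2cc(NC(=O)c3ccc(C)c(Oc4ccccc4)c3)cc(N3CCN(C)CC3)c2)cn1` holds the higher of the two numbers recorded in an ADME assay on the whole organism (Mus musculus, strain CD1) for metabolic stability, read by LC-MS, using cassette dosing, with a stated time of 24 h, at a dose of 0.4 mg/kg by the intravenous route (on this read-out higher numbers stand for a longer-lived compound and lower numbers for a shorter-lived compound), giving 7.36 h. Compound 1 `Cc1cn(-c2cc(NC(=O)c3ccc(C)c(Oc4ccccc4)c3)cc(C(F)(F)F)c2)cn1` gives 2.15 h in this assay, and the step of a 3.4-fold higher number from compound 1 to compound 2 (0.53 log units; beyond the scatter) is the only one measured. Compound 3 `Cc1cn(-c2cc(CN3CCC[C@H](N)C3)cc(NC(=O)c3ccc(C)c(Oc4ccccc4)c3)c2)cn1` differs from compound 2 by (3-aminopiperidin-1-yl)methyl in place of 4-methylpiperazin-1-yl on an aromatic carbon. For the measured compounds named here, no measured step covers this exchange; the only step seen concerns a different substituent, so it bears on it only loosely. Compound 3 is therefore expected to lie within the scatter of compound 2, with an estimated step of a 1.2-fold lower number from compound 2 to compound 3 (0.09 log units; within the scatter). The estimated half-life for compound 3 is 6 h, spanning 2.5 h to 13 h.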

Compound 3, half-life: 25.7 h
Beside the measured number, compound 3's estimate is 4.3-fold (0.63 log units) below it; the whole stated range lies below it.
By their numbers in this assay, from the lowest: compound 1; then compound 2; then compound 3.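

In this assay the swap of 4-methylpiperazin-1-yl for (3-aminopiperidin-1-yl)methyl gives a 3.5-fold higher number from compound 2 to compound 3 (0.54 log units; beyond the scatter) and shows that half-life at this position can still rise well past the level of compound 2. Set against trifluoromethyl, the same group gives a 12-fold higher number from compound 1 to compound 3 (1.08 log units; beyond the scatter) and turns a modest gain into a large one. No evidence in hand accounts for this rise.

On these data alone, whether the gain goes with the methyl link or with the amine stays open, and a (4-methylpiperazin-1-yl)methyl group at this place would separate the two. The compounds shown also leave open how the opposite configuration at the defined stereocentre would behave.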